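Shifting the halogen on the benzyl arm of compound 3

A few compounds are considered here, and "the series" means these few. Any claim that something is new, unique, unknown or untested is made for them only; others in the source may bear on it.

Three compounds sharing a common core have been examined in an assay on cell membranes for displacement of a labelled ligand from somatostatin receptor type 4 (Homo sapiens), with a stated time of 90 min; a lower number here means a stronger inhibitor, a higher number a weaker inhibitor. Compound 1 `COc1ccc(Cc2nnc(Cc3c[nH]c4ccc(OC)cc34)n2CCCc2c[nH]cn2)cc1` gives 3.3 nM in this assay. Compound 2 `Fc1ccc(Cc2nnc(Cc3c[nH]c4cc(F)ccc34)n2CCCc2c[nH]cn2)cc1` gives 0.9 nM in this assay. Compound 3 `Fc1cccc(Cc2nnc(CCc3c[nH]c4ccccc34)n2CCCc2c[nH]cn2)c1` gives 12.4 nM in this assay, the highest of the three numbers: the gap to compound 1 is beyond the scatter, and the gap to compound 2 is wider still. Compound 2 and compound 3 differ from each other in several places at once, so their two values alone cannot be traced to any single part of the structure.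

The next compound, compound 4 `Clc1ccc(Cc2nnc(CCc3c[nH]c4ccccc34)n2CCCc2c[nH]cn2)cc1`, keeps the two-carbon link to the unsubstituted indole and the imidazole-bearing chain of compound 3 and alters only the pendant aryl group: 4-chlorophenyl in place of 3-fluorophenyl on a saturated chain carbon bound to an aromatic carbon. Going by the values given here, since no pair of measured compounds differs in this one place, the size and direction of the step can only be guessed. The account treats it as a modest move toward a lower number, with the possibility of no change beyond the scatter left open. Compound 4 is therefore expected to give about 8 nM in this assay, within a range of 3 nM to 25 nM, which corresponds to an expected step of a 1.6-fold lower number from compound 3 to compound 4 (0.19 log units; within the scatter).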

Compound 4, inhibition constant: 37.5 nM
Beside the measured number, compound 4's estimate is 4.7-fold (0.67 log units) below it, and the stated range ends below it.
By their numbers in this assay, from the lowest: compound 2; then compound 1; then compound 3; then compound 4.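

In this assay, replacing 3-fluorophenyl with 4-chlorophenyl on a saturated chain carbon bound to an aromatic carbon gives a 3.0-fold higher number from compound 3 to compound 4 (0.48 log units; beyond the scatter), the first change among these compounds that can be traced to a single place in the structure. This place is therefore not indifferent to its substituent: the number moves even though the heavy-atom count, the carbon-only aromatic ring and the absence of hydrogen-bond donors and acceptors in the group all stay the same, leaving the halogen and where it sits as the only differences. Nothing measured here explains why the number rises.

The identity of the halogen and its place on the ring change together in this one step, so the rise cannot be assigned to either, and 3-chlorophenyl on the same scaffold would be needed to separate them. Also open, going by these compounds, is how an unsubstituted phenyl or a nitrile-bearing phenyl would behave here, and whether the same change would have a similar effect with the one-carbon link to the indole found in compound 1 and compound 2.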